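The source may hold more compounds than are shown below. What is called first, only, known or untested is meant among the compounds shown, and "the series" means these compounds.

Compound 1 `O=C(CCc1cccc2c1B(O)OC2)Nc1ccccc1`: 230 nM
Compound 2 `O=C(CCc1cccc2c1B(O)OC2)Nc1cccc(I)c1`: 5300 nM
Compound 3 `O=C(CCc1cccc2c1B(O)OC2)Nc1cccc(-c2ccccc2)c1`: 220 nM

These values come from a functional assay on MDA-MB-231 cells (Homo sapiens) for antiproliferative activity, read by MTT assay, with a stated time of 72 h; on this read-out lower numbers stand for stronger inhibition and higher numbers for weaker inhibition. Compound 3 sits level with compound 1, as a 1.0-fold lower number from compound 1 to compound 3 (0.02 log units; within the scatter) shows, and far from compound 2, as a 24-fold lower number from compound 2 to compound 3 (1.38 log units; beyond the scatter) shows.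

Compound 4 `O=C(CCc1cccc2c1B(O)OC2)Nc1cccc(-c2ccc(F)cc2)c1` has not yet been measured. It has fluoro in place of hydrogen on an aromatic carbon, so the phenyl of compound 3 becomes 4-fluorophenyl: fluoro in place of hydrogen on an aromatic carbon.

Within the data shown here, no measured step adds fluoro, so the evidence is indirect. Adding phenyl to compound 1 made no real difference, with a 1.0-fold lower number from compound 1 to compound 3 (0.02 log units; within the scatter). Adding iodo was far from neutral, with a 23-fold higher number from compound 1 to compound 2 (1.36 log units; beyond the scatter), so a small substitution can matter in this series. That iodo sits at a different place, however, and is a different group. A step within the scatter is therefore expected in this assay, with some risk of a weaker result.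

The expected change is a 1.1-fold higher number from compound 3 to compound 4 (0.04 log units; within the scatter).

For compound 4 the estimated value is 240 nM, with an expected range of 90 nM to 650 nM.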

Compound 4, half-maximal inhibitory concentration: 250 nM
The estimate for compound 4 lay 1.0-fold (0.02 log units) below the measured number; the range from low to high includes it.
By their numbers in this assay, from the lowest: compounds 3, 1 and 4 (each within the scatter of the next); then compound 2.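

In this assay, the phenyl added in compound 3 accepts a further group: the change from phenyl to 4-fluorophenyl gives a 1.1-fold higher number from compound 3 to compound 4 (0.06 log units; within the scatter), so this outer ring can carry fluoro with no real change in the number. Against the core of compound 1, the whole 4-fluorophenyl group also gives only a 1.1-fold higher number from compound 1 to compound 4 (0.04 log units; within the scatter), which extends what phenyl alone showed. In the place held by iodo, it gives a 21-fold lower number from compound 2 to compound 4 (1.33 log units; beyond the scatter), so the weak result of compound 2 does not return with this larger group.

No measurement shown explains why these groups behave so differently. From the compounds shown here alone, it also remains open whether an amine, a carboxylic acid or a longer chain in place of the fluoro would leave the number as unchanged.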